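The source may report more compounds than this note shows. Statements on the series, on what has been measured and on what is new or still open speak of the compounds shown alone.

Compound 1 `C=C(Br)C(=O)Nc1ccc2c(c1)/C(=C\c1cccs1)C(=O)N2` bears a thiophen-2-yl group on the shared core, which compound 2 `C=C(Br)C(=O)Nc1ccc2c(c1)CC(=O)N2` lacks. In a functional assay on RS4-11 cells (Homo sapiens) for antiproliferative activity, read by MTT assay, with a stated time of 72 h (on this read-out lower numbers stand for stronger inhibition and higher numbers for weaker inhibition), compound 2 gives 220 nM. In this assay compound 1 gives 530 nM, the higher of the two numbers, and the gap between the two lies beyond the usual scatter. Compound 3 `C=C(Br)C(=O)Nc1ccc2c(c1)/C(=C\c1sccc1C)C(=O)N2` has not yet been measured. It differs from compound 1 by methyl in place of hydrogen on an aromatic carbon. Going by the values given here, no measured pair in this set shows what such a change does, so the expectation rests on the small size of the change alone. The step of a 1.2-fold lower number from compound 1 to compound 3 (0.07 log units; within the scatter) is expected to be small, in no direction that would stand out beyond the scatter. Compound 3 is therefore estimated at 450 nM, within a range from 180 nM to 1100 nM.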

Compound 3, half-maximal inhibitory concentration: 4 nM
The estimate for compound 3 lay 110-fold (2.05 log units) above the measured number, outside the stated range (below it).
By their numbers in this assay, from the lowest: compound 3; then compound 2; then compound 1.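

In this assay the change from thiophen-2-yl to 3-methylthiophen-2-yl gives a 130-fold lower number from compound 1 to compound 3 (2.12 log units; beyond the scatter) and so shows that this ring carbon, next to the ring atom that bears a large group, is highly sensitive to substitution. The earlier compounds shown here said nothing about substitution on this ring; here, a single added carbon with no hydrogen-bond donors or acceptors moves the number far beyond the scatter. Nothing in the data shown accounts for the size of this step.

The compounds shown leave open whether methyl is unusual at this carbon or whether an ethyl group, a chlorine atom or a methoxy group would serve as well. They also leave open whether methyl on another carbon of the same ring would give a comparable step.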